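The source may hold more compounds than are shown below. What is called first, only, known or untested is meant among the compounds shown, and "the series" means these compounds.

Measured so far:
Compound 1 `CCN(CC)Cc1cc(Nc2nc3ccccc3n2Cc2ccc(C(F)(F)F)cc2)ccc1O`: 17500 nM
Compound 2 `CCN(CC)Cc1cc(Nc2nc3ccccc3n2Cc2ccc(F)cc2)ccc1O`: 12000 nM
Compound 3 `CCN(CC)Cc1ccc(Nc2nc3ccccc3n2Cc2ccc(F)cc2)cc1O`: 45800 nM

All three were tested in an ADME assay on CHO cells (Cricetulus griseus) for inhibition, read by MTT assay; on this read-out higher numbers stand for weaker inhibition and lower numbers for stronger inhibition. Compound 4 `CCN(CC)Cc1ccc(Nc2nc3ccccc3n2Cc2ccc(C(F)(F)F)cc2)cc1O` has not yet been measured in this assay.

Compound 2 and compound 1 share a core and differ in one place: trifluoromethyl in place of fluoro on an aromatic carbon. That change brought a 1.5-fold higher number from compound 2 to compound 1 (0.16 log units; within the scatter), so on this read-out the two compounds cannot be told apart. Compound 3 is built from the same atoms as compound 2, joined differently; the difference between the two cores is not broken down here. On the values alone, compound 3 gives the highest number of the three, with compound 1 nearer to it and compound 2 furthest away.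

Compound 4 is related to compound 3 as compound 1 is to compound 2: trifluoromethyl in place of fluoro on an aromatic carbon. The change sits at a place described in the same words in both pairs, so it is the same change on a different core. Going by the values given here, the only guide to its effect is the pair from compound 2 to compound 1, where it made a step within the scatter. If compound 4 behaves the same way, the expected step is a 1.4-fold higher number from compound 3 to compound 4 (0.15 log units; within the scatter), resting on a 1.5-fold higher number from compound 2 to compound 1 (0.16 log units; within the scatter). Compound 4 is therefore expected to give about 65000 nM in this assay, with a likely range from 28000 nM to 150000 nM. One example of the change on one other core is a thin basis, and the expectation is correspondingly uncertain.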

Compound 4, half-maximal inhibitory concentration: 41500 nM
Compound 4: the middle estimate sits 1.6-fold (0.19 log units) above what was measured; the measured number falls inside the stated range.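

In this assay, putting trifluoromethyl in place of fluoro on the second core brought a 1.1-fold lower number from compound 3 to compound 4 (0.04 log units; within the scatter), so on this read-out the two compounds cannot be told apart. Set beside the earlier pair, the change behaves alike on both cores, with each step too small to count and no real gap between the two: the same change on two cores in this assay, a 1.5-fold higher number (0.16 log units; within the scatter) from compound 2 to compound 1 and a 1.1-fold lower number (0.04 log units; within the scatter) from compound 3 to compound 4, 1.6-fold (0.21 log units) apart, within the scatter of two such steps. From the compounds shown here alone, this shows that, in these two pairs, going from 4-fluorobenzyl to 4-(trifluoromethyl)benzyl leaves the number within the scatter on either core, but it does not show that the change is without effect in general; two pairs are a small sample, steps this small could hide a slight real effect in either direction, and other cores remain untested by these data.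

The compounds shown leave open what other groups would do at this same place on the aromatic ring, for example chloro, methoxy, a nitrile or an amine. They also leave open whether any such group would move the number beyond the scatter on one core but not on the other, which would show that the two cores respond differently.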